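The source may report more compounds than this note shows. Statements on the series, on what has been measured and on what is new or still open speak of the compounds shown alone.

Measured so far in a functional assay on FM3A cells (Mus musculus) for antiproliferative activity; on this read-out higher numbers stand for weaker inhibition and lower numbers for stronger inhibition:
- compound 1 `COc1cc(C(=O)c2sc(-c3ccc(I)cc3)cc2N)cc(OC)c1OC`: 420 nM
- compound 2 `COc1cc(C(=O)c2sc(-c3cccc([N+](=O)[O-])c3)cc2N)cc(OC)c1OC`: 17 nM

Compound 2 holds the lower of the two numbers. Among the measured compounds shown here, the only measured step is a 25-fold lower number from compound 1 to compound 2 (1.39 log units; beyond the scatter), which is large and beyond the scatter. It places 3-nitrophenyl where 4-iodophenyl stood on an aromatic carbon.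

Still unmeasured is compound 3 `COc1cc(C(=O)c2sc(-c3ccc(Cl)c(Cl)c3)cc2N)cc(OC)c1OC`. It differs from compound 2 at that same aryl position: 3,4-dichlorophenyl in place of 3-nitrophenyl on an aromatic carbon. In words, this is 3,4-dichlorophenyl in place of 3-nitrophenyl on an aromatic carbon, next to the ring sulfur.

For the measured compounds named here, one step is thin ground, and no measured compound carries this exact group. Even so, compound 3 gives up the 3-nitrophenyl and, like compound 1 at 420 nM, bears a halogen-substituted phenyl. A move towards a higher number in this assay is therefore expected, though smaller than a 25-fold lower number from compound 1 to compound 2 (1.39 log units; beyond the scatter), since the two chlorines are not the single iodine. The expected change is a 7.1-fold higher number from compound 2 to compound 3 (0.85 log units; beyond the scatter). For compound 3 the estimated value is 120 nM, with an expected range of 30 nM to 500 nM.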

Compound 3, half-maximal inhibitory concentration: 400 nM
Beside the measured number, compound 3's estimate is 3.3-fold (0.52 log units) below it, within the range that was stated.
By their numbers in this assay, from the lowest: compound 2; then compounds 3 and 1 (each within the scatter of the next).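

In this assay, replacing 3-nitrophenyl with 3,4-dichlorophenyl gives a 24-fold higher number from compound 2 to compound 3 (1.37 log units; beyond the scatter), so this position on the aromatic carbon next to the ring sulfur is now seen to respond strongly to a second aryl group as well, and the low number of compound 2 does not carry over to this replacement. Against 4-iodophenyl, the same group gives a 1.1-fold lower number from compound 1 to compound 3 (0.02 log units; within the scatter), which leaves the two halogen-bearing phenyl groups indistinguishable on this read-out despite their different halogens and substitution, and among these three compounds only the 3-nitrophenyl group stands apart. Nothing on hand accounts for the separation of compound 2 from the two halogen-bearing compounds.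

On these data alone, it remains open whether the low number of compound 2 depends on the nitro group itself or would also appear with 3-aminophenyl, 3-cyanophenyl or 4-nitrophenyl at this place. The three compounds also leave open whether 3-chlorophenyl, with a single chlorine, or unsubstituted phenyl would read like the two halogen-bearing groups or like 3-nitrophenyl.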